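The compounds below may be only part of what the source reports. "The series", "measured", "known", "first", "only" and "open" are said of these compounds alone.

Among the measured compounds shown here, compound 1 `COc1ccc(NC2=CC(=O)c3ncncc3C2=O)cc1` is the only member of this small set with a measured number in a functional assay on MIA PaCa-2 cells (Homo sapiens) for cytotoxicity, read by MTT assay, with a stated time of 72 h; on this read-out higher numbers stand for weaker inhibition and lower numbers for stronger inhibition. In this assay compound 1 gives 1900 nM. Compound 2 `NS(=O)(=O)c1ccc(NC2=CC(=O)c3ncncc3C2=O)cc1` carries a sulfamoyl group where compound 1 has a methoxy group. In this assay compound 2 reaches only the limit > 10000 nM, so no number is reported for it. The step of an at least 5.2-fold higher number from compound 1 to compound 2 (0.72 log units; beyond the scatter) can therefore only be bounded, and the bound rests on (the limit of > 10000 nM in this assay, at which 1 of the 2 values shown sits). Compound 3 `COc1ccc(NC2=CC(=O)c3ncncc3C2=O)cc1OC` is not yet measured in this assay. It differs from compound 1 by methoxy in place of hydrogen on an aromatic carbon. For the measured compounds named here, the one measured step exchanges the methoxy group itself for a sulfamoyl group, a change of a different kind, so it says little about adding a second methoxy group next to the first; no measured step directly covers this change. With that thin basis, compound 3 is expected to sit close to compound 1, and the change no change at the digits printed from compound 1 to compound 3 (within the scatter) is estimated to stay within the scatter. Compound 3 is accordingly estimated at 1900 nM, with a range from 600 nM to 6000 nM.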

Compound 3, half-maximal inhibitory concentration: 1800 nM
Estimate against measurement, compound 3: 1.1-fold (0.02 log units) above, and the stated range covers the measured number.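

In this assay, among the compounds shown here, the step of a 1.1-fold lower number from compound 1 to compound 3 (0.02 log units; within the scatter) gives the first reading at this position, on an aromatic carbon ortho to a methoxy group and meta to a large group. The earlier step exchanged the existing methoxy group for a sulfamoyl group, whereas this one keeps that group and adds a second methoxy group, and at this carbon a substituent of 2 heavy atoms (1 carbon, 1 oxygen) leaves the read-out within the scatter. Nothing in the information at hand offers a reason for this result.

What the compounds shown leave open is whether this position would accept other groups in the same way, for example a longer chain such as butoxy, an amine or a carboxylic acid, since methoxy is the only group shown there. They also leave open whether a hydroxyl group or a chlorine atom in place of the original methoxy group of compound 1 would keep the read-out close to that of compound 1, since sulfamoyl is the only replacement of that group shown.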